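This account rests on a few compounds, and the source may have more. Where it says the series, first, only, none or still open, it means among the compounds named here.

Measured in a functional assay on MCF7 cells (Homo sapiens) for antiproliferative activity, read by MTT assay, with a stated time of 48 h; a higher number here means a weaker inhibitor, a lower number a stronger inhibitor:
- compound 1 `COc1cc(-c2nnc3c(OC)cc(-c4ccc5[nH]ccc5c4)cn23)cc(OC)c1OC` gives 80 nM
- compound 2 `COc1cc(-c2nnc3c(OC(C)C)cc(-c4ccc5[nH]ccc5c4)cn23)cc(OC)c1OC` gives 1020 nM
- compound 3 `COc1cc(-c2nnc3c(OC4COC4)cc(-c4ccc5[nH]ccc5c4)cn23)cc(OC)c1OC` gives 2470 nM

Compound 1 has the lowest number of the three and is the strongest inhibitor here, with both other compounds beyond the scatter from it. Next in the series is compound 4 `COc1cc(-c2nnc3c(OC)cc(-c4ccc5c(ccn5C)c4)cn23)cc(OC)c1OC`, which differs from compound 1 by methyl in place of hydrogen on an aromatic nitrogen.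

Going by the values given here, no measured step changes this nitrogen. Among the compounds with values here, the only evidence comes from the group on the oxygen, where the series responds strongly: a 13-fold higher number from compound 1 to compound 2 (1.11 log units; beyond the scatter) and a 31-fold higher number from compound 1 to compound 3 (1.49 log units; beyond the scatter) are both large, while a 2.4-fold higher number from compound 2 to compound 3 (0.38 log units; beyond the scatter) is modest. These steps show that a small change to compound 1 can cost much activity, but they were made at a different place and do not transfer directly. A modest move towards a higher number in this assay is therefore expected, with little confidence in its size, and no change beyond the scatter remains possible.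

The expected change is a 2.0-fold higher number from compound 1 to compound 4 (0.30 log units; within the scatter), a cautious estimate. For compound 4 the estimated value is 160 nM, with an expected range from 45 nM to 600 nM.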

Compound 4, half-maximal inhibitory concentration: 49 nM
Compound 4: the middle estimate sits 3.3-fold (0.51 log units) above what was measured, within the range that was stated.
By their numbers in this assay, from the lowest: compounds 4 and 1 (each within the scatter of the next); then compound 2; then compound 3.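

In this assay, methyl in place of hydrogen on the aromatic nitrogen gives a 1.6-fold lower number from compound 1 to compound 4 (0.21 log units; within the scatter), so the 1-methyl-1H-indol-5-yl group reads the same as the 1H-indol-5-yl group within the scatter. This position therefore tolerates the added carbon, in contrast to the group on the oxygen, where a 13-fold higher number from compound 1 to compound 2 (1.11 log units; beyond the scatter) and a 31-fold higher number from compound 1 to compound 3 (1.49 log units; beyond the scatter) are large steps. Nothing at hand bears on why this step stays so small.

A single methyl leaves open how large a group this nitrogen accepts: an ethyl, a longer chain, or a chain ending in an amine or a carboxylic acid would probe that limit. Also open, as far as these compounds go, is whether isopropyl or oxetan-3-yl on the oxygen costs as much when methyl sits on the nitrogen.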